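Bromo for chloro on a weakly cytotoxic compound

A few compounds are considered here, and "the series" means these few. Any claim that something is new, unique, unknown or untested is made for them only; others in the source may bear on it.

Within the data shown here, in a functional assay on KB cells (Homo sapiens) for cytotoxicity, read by spectrophotometry and crystal violet staining (on this read-out higher numbers stand for weaker inhibition and lower numbers for stronger inhibition), compound 1 `CC(=O)c1c(Cl)n([C@H]2C[C@H](O)[C@@H](CO)O2)c2cc(Cl)c(Cl)cc12` gives 400000 nM, the highest of the three numbers so far. Compound 2 `N#Cc1c(Cl)n([C@H]2C[C@H](O)[C@@H](CO)O2)c2cc(Cl)c(Cl)cc12` gives 60000 nM, and compound 3 `OC[C@H]1O[C@@H](n2c(Cl)c(-c3ccsc3)c3cc(Cl)c(Cl)cc32)C[C@@H]1O` gives 50000 nM. Compound 4 `CC(=O)c1c(Br)n([C@H]2C[C@H](O)[C@@H](CO)O2)c2cc(Cl)c(Cl)cc12` differs from compound 1 at one place, with bromo in place of chloro on an aromatic carbon. Among the measured compounds shown here, no measured step touches this chloro. The nearest evidence comes from replacing the acetyl group, with modest steps of a 6.7-fold lower number from compound 1 to compound 2 (0.82 log units; beyond the scatter) and an 8.0-fold lower number from compound 1 to compound 3 (0.90 log units; beyond the scatter), so it bears only loosely on this swap. The expected step in this assay is a 1.3-fold lower number from compound 1 to compound 4 (0.12 log units; within the scatter), which means no shift beyond the scatter is expected. Compound 4 is estimated at 300000 nM, with an expected range from 100000 nM to 600000 nM.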

Compound 4, half-maximal inhibitory concentration: > 100000 nM
Compound 4: only a limit was reported (the forecaster's own chance of this, stated with the estimate: 10%); the middle value does not contradict the limit.
By their numbers in this assay, from the lowest: compounds 3 and 2 (each within the scatter of the next); then compound 1.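

In this assay, among these compounds, compound 4 is reported as the limit > 100000 nM and not as a number, so no step from compound 1 to compound 4 can be read. The compounds shown leave open whether bromo in place of chloro changes the number at all.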